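Changing the aryl group on a sulfonyl sulfur

A few compounds are considered here, and "the series" means these few. Any claim that something is new, unique, unknown or untested is made for them only; others in the source may bear on it.

Values measured so far in a functional assay on HeLa cells (Homo sapiens) for cytotoxicity, read by sulforhodamine B assay (on this read-out higher numbers stand for weaker inhibition and lower numbers for stronger inhibition), are these:
compound 1 `Cc1ccc(S(=O)(=O)NC(C)C2=CC(=O)c3c(O)ccc(O)c3C2=O)cc1` gives 5340 nM
compound 2 `Cc1ccccc1S(=O)(=O)NC(C)C1=CC(=O)c2c(O)ccc(O)c2C1=O` gives 4490 nM

Compound 2 at 4490 nM cannot be told apart from compound 1 on these numbers. Going by the values given here, the only measured step is a 1.2-fold lower number from compound 1 to compound 2 (0.08 log units; within the scatter) and it stays within the scatter.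

Compound 3 `COc1ccc(S(=O)(=O)NC(C)C2=CC(=O)c3c(O)ccc(O)c3C2=O)c(OC)c1` keeps the shared core and carries 2,4-dimethoxyphenyl in place of 2-methylphenyl on a sulfonyl sulfur, a change counted as 2,4-dimethoxyphenyl in place of 2-methylphenyl on a sulfonyl sulfur with no value yet to show for it. Among the compounds with values here, that single step, 2-methylphenyl in place of 4-methylphenyl, is the only guide, and no measured compound carries a methoxy group. No shift beyond the scatter is therefore expected in this assay and the estimate is a 1.1-fold higher number from compound 2 to compound 3 (0.03 log units; within the scatter) with wide uncertainty. Compound 3 is estimated at 4800 nM and is expected to fall between 1900 nM and 12000 nM.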

Compound 3, half-maximal inhibitory concentration: 19500 nM
Compound 3: the middle estimate sits 4.1-fold (0.61 log units) below what was measured; the measured number lies above the stated range.
By their numbers in this assay, from the lowest: compounds 2 and 1 (each within the scatter of the next); then compound 3.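

In this assay, the aryl group on the sulfonyl sulfur turns out to matter: placing 2,4-dimethoxyphenyl there gives a 4.3-fold higher number from compound 2 to compound 3 (0.64 log units; beyond the scatter) and likewise a 3.7-fold higher number from compound 1 to compound 3 (0.56 log units; beyond the scatter). Going by these compounds alone, on this read-out the higher number stands for weaker inhibition, so compound 3 is the first compound to separate from the others, whereas the two methylphenyl compounds could not be told apart. No available evidence bears on this result.

The compounds shown leave open whether the two methoxy groups are both needed for this shift or whether one alone would produce it. Also open, going by these compounds, is how a plain phenyl, a chlorophenyl or an aminophenyl group would read on the sulfonyl sulfur.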